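Putting 4-Fluorophenyl on an Aromatic Carbon

The source may report more compounds than this note shows. Statements on the series, on what has been measured and on what is new or still open speak of the compounds shown alone.

In a toxicity assay on HepG2 2.2.15 cells (Homo sapiens) for cytotoxicity, read by CellTiter-Glo (on this read-out higher numbers stand for lower toxicity in this test and lower numbers for higher toxicity in this test), compound 1 `O=C1CC(Oc2ncc(F)cn2)CN1c1cnn2c1CN(C(=O)Nc1cc(F)c(F)c(F)c1)C(C1CC1)C2` gives 96200 nM and compound 2 `O=C1CC(C(F)(F)F)CN1c1cnn2c1CN(C(=O)Nc1cc(F)c(F)c(F)c1)C(C1CC1)C2` gives 115000 nM. For the measured compounds named here, these are the only two numbers so far, and they cannot be told apart: the one measured step is a 1.2-fold higher number from compound 1 to compound 2 (0.08 log units; within the scatter). Compound 2 therefore stands level with compound 1, and neither can be ranked above the other.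

Compound 3 `O=C(Nc1cc(F)c(F)c(F)c1)N1Cc2c(-c3ccc(F)cc3)cnn2CC1C1CC1` differs from compound 2 in a larger way, with 4-fluorophenyl in place of 2-oxo-4-(trifluoromethyl)pyrrolidin-1-yl on an aromatic carbon. The measured step only exchanged a group on a saturated ring carbon, while here the whole five-membered non-aromatic ring leaves. Going by the values given here, no measured step covers such a replacement, so the evidence is thin and any forecast must stay wide. Compound 2 already gives a high number at 115000 nM, so a fall seems more likely than a rise. The expected step is a 2.3-fold lower number from compound 2 to compound 3 (0.36 log units; beyond the scatter), which would mean somewhat higher toxicity in this test. Compound 3 is estimated at 50000 nM, with an expected range from 15000 nM to 130000 nM.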

Compound 3, half-maximal cytotoxic concentration: 38500 nM
The estimate for compound 3 lay 1.3-fold (0.11 log units) above the measured number, within the range that was stated.
By their numbers in this assay, from the lowest: compound 3; then compounds 1 and 2 (each within the scatter of the next).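

In this assay, putting 4-fluorophenyl in place of 2-oxo-4-(trifluoromethyl)pyrrolidin-1-yl on the aromatic carbon gives a 3.0-fold lower number from compound 2 to compound 3 (0.48 log units; beyond the scatter), a modest move towards higher toxicity in this test. The earlier step, a 1.2-fold higher number from compound 1 to compound 2 (0.08 log units; within the scatter), exchanged only a group on a saturated ring carbon of the five-membered non-aromatic ring, so this is the first sign that the number can respond to a change among these compounds, here one that removes that whole ring and puts a six-membered aromatic ring of carbon only on the aromatic carbon. No measurement of any other property accompanies this result, and the reason for the fall remains unknown.

This single step swaps the whole group at once, so the compounds shown leave open whether the lower number goes with the loss of the five-membered non-aromatic ring or with the arrival of the aromatic ring. Also open, going by these compounds, is how a plain phenyl without its fluorine, or a morpholine or a carboxylic acid, would read on the same aromatic carbon of the shared core.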